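A few compounds are considered here, and "the series" means these few. Any claim that something is new, unique, unknown or untested is made for them only; others in the source may bear on it.

Of the compounds shown here, three have so far been measured in a functional assay on the whole organism (strain Wistar) for inhibition, with Rattus norvegicus as the target, read by paw edema, at a dose of 100 mg/kg by the oral route; a lower number here means less inhibition, a higher number more inhibition at the dose given (going by the name of the read-out). Compound 1 `O=C(O)CNc1nc(-c2ccccc2)nc2ccccc12` gives 0%, and compound 2 `O=C(O)CNc1nc(-c2ccccc2)nc2ccc(Br)cc12` gives 0%; the change between them is bromo in place of hydrogen on an aromatic carbon, and the step is no change at the digits printed from compound 1 to compound 2 (within the scatter). Compound 3 `CC[C@H](C)[C@H](Nc1nc(-c2ccccc2)nc2ccccc12)C(=O)O` differs from compound 1 by sec-butyl in place of hydrogen on a saturated chain carbon bound to a carbonyl carbon and a nitrogen on an aromatic ring. In this assay compound 3 gives 4.1%, a step of a number 4.1 percentage points higher from compound 1 to compound 3 (within the scatter). Compound 4 `CC[C@H](C)[C@H](Nc1nc(-c2ccccc2)nc2ccc(Br)cc12)C(=O)O` has not yet been measured in this assay; it differs from compound 3 by bromo in place of hydrogen on an aromatic carbon, the same change that separates compound 1 from compound 2, made on a core that carries the sec-butyl group. Because that change gave no change at the digits printed from compound 1 to compound 2 (within the scatter), compound 4 is expected to show a step of a number 0.1 percentage points lower from compound 3 to compound 4 (within the scatter). Compound 4 is therefore estimated at 4%, with a likely range from 0% to 14%.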

Compound 4, a percentage reported as inhibition, in the whole organism at one dose (the size of the read-out at that dose, not a potency): 0%
Compound 4: the middle estimate sits 4 percentage points above what was measured; low and high end bracket the measured number.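

In this assay, the step for bromo in place of hydrogen on the core carrying the sec-butyl group is a number 4.1 percentage points lower from compound 3 to compound 4 (within the scatter), and the step for sec-butyl in place of hydrogen on the bromo-bearing core is no change at the digits printed from compound 2 to compound 4 (within the scatter). The bromo change reads alike on both cores: the same change on two cores in this assay, no change at the digits printed (within the scatter) from compound 1 to compound 2 and a number 4.1 percentage points lower (within the scatter) from compound 3 to compound 4, 4.1 percentage points apart, within the scatter of two such steps The sec-butyl change also reads alike on both cores: the same change on two cores in this assay, a number 4.1 percentage points higher (within the scatter) from compound 1 to compound 3 and no change at the digits printed (within the scatter) from compound 2 to compound 4, 4.1 percentage points apart, within the scatter of two such steps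

Among the compounds shown here, every one of these steps lies within the scatter, which shows only that neither change carried a measurable shift between these cores, not how either would behave on a core with clear inhibition. The compounds shown leave open what a chloro or methoxy group in place of the bromo would give. They also leave open what an ester or an amide in place of the carboxylic acid would give.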